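This account rests on a few compounds, and the source may have more. Where it says the series, first, only, none or still open, it means among the compounds named here.

Working notes on the series. Compound 2 `CC1(COc2ccc(C(F)(F)F)cc2)Cn2cc([N+](=O)[O-])nc2O1` and compound 1 `CC1(COc2ccc(OC(F)(F)F)cc2)Cn2cc([N+](=O)[O-])nc2O1` share one core; compound 3 `O=[N+]([O-])c1cn2c(n1)OC(COc1ccc(-c3ccc(C(F)(F)F)cc3)cc1)C2` carries another, and the difference between the two cores is not broken down here. In an ADME assay on MRC5 cells (Homo sapiens) for cytotoxicity, read by fluorescence, with a stated time of 72 h (a lower number here means a stronger inhibitor, a higher number a weaker inhibitor), compound 2 gives > 64000 nM, which is a limit of the assay and not a number. Compound 1 gives > 64000 nM in this assay, also a limit. Compound 3 gives > 64000 nM in this assay, again a limit. From compound 2 to compound 1 the change is trifluoromethoxy in place of trifluoromethyl on an aromatic carbon; its step that the two limits leave unreadable from compound 2 to compound 1 cannot be sized because of the limit of > 64000 nM in this assay, at which 3 of the 3 values shown sit. Compound 4 `O=[N+]([O-])c1cn2c(n1)OC(COc1ccc(-c3ccc(OC(F)(F)F)cc3)cc1)C2` is not yet measured and differs from compound 3 by trifluoromethoxy in place of trifluoromethyl on an aromatic carbon, the same change as that from compound 2 to compound 1. For the measured compounds named here, no measured step gives a size for this change. The step from compound 3 to compound 4 is therefore expected to be a step that the limit leaves unreadable from compound 3 to compound 4, essentially flat. This expectation rests on compound 3, whose result in this assay is > 64000 nM, a limit. Compound 4 is accordingly estimated at 100000 nM in this assay, between 40000 nM and 300000 nM, most likely reported as a limit once more.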

Compound 4, half-maximal inhibitory concentration: > 64000 nM
Compound 4: no number, only a limit; the forecaster's own chance of this, stated with the estimate: 85%; the middle value is on the limit's open side.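

No step can be read from compound 3 to compound 4, because both results are limits of the assay and not numbers: the limit of > 64000 nM in this assay, at which 4 of the 4 values shown sit.

The compounds shown leave open how large the change from trifluoromethyl to trifluoromethoxy is in this assay, and which structures in this series, if any, would give a number there rather than a limit.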